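Ring amine in place of dimethylamino on a pyridine core

The source may hold more compounds than are shown below. What is called first, only, known or untested is meant among the compounds shown, and "the series" means these compounds.

Measured so far:
Compound 1, `CC(C(=O)NCc1ccc(C(F)(F)F)nc1NCC1CCN(C(=O)OC(C)(C)C)CC1)c1ccc(NS(C)(=O)=O)c(F)c1`, gives 1140 nM in a functional assay on CHO-K1 cells for antagonist activity at transient receptor potential cation channel subfamily V member 1 (Homo sapiens), read by FLIPR; a lower number here means a stronger inhibitor, a higher number a weaker inhibitor.
Compound 2, `CC(C(=O)NCc1ccc(C(F)(F)F)nc1N(C)C)c1ccc(NS(C)(=O)=O)c(F)c1`, gives 2390 nM in this assay.
Compound 3, `C[C@H](C(=O)NCc1ccc(C(F)(F)F)nc1N1CC[C@@H](OCc2ccccc2)C1)c1ccc(NS(C)(=O)=O)c(F)c1`, gives 50 nM in this assay.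

Compound 2 stands at the highest number of the three, which makes it the weakest inhibitor of this small set: compound 1 sits at a number that is lower by an amount beyond the scatter, and compound 3 sits far lower still.

Compound 4, `CC(C(=O)NCc1ccc(C(F)(F)F)nc1N1CCC(c2ccccc2)CC1)c1ccc(NS(C)(=O)=O)c(F)c1`, has not yet been measured. It differs from compound 2 in one place: 4-phenylpiperidin-1-yl in place of dimethylamino on an aromatic carbon. Compound 3 shows that a ring amine carrying an aromatic ring at this position goes with a much lower number than the dimethylamino of compound 2: compound 3 gives 50 nM, where compound 2 gives 2390 nM. Going by the values given here, no directly comparable step is known, so the expectation rests on that comparison. The step of a 16-fold lower number from compound 2 to compound 4 (1.20 log units; beyond the scatter) is expected to be a clear drop, well beyond the scatter. Compound 4 is therefore estimated at 150 nM, within a range from 40 nM to 600 nM.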

Compound 4, half-maximal inhibitory concentration: 25 nM
For compound 4 the middle estimate is 6.0-fold (0.78 log units) above the measured one; measured number outside the range, below it.
By their numbers in this assay, from the lowest: compounds 4 and 3 (each within the scatter of the next); then compound 1; then compound 2.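

In this assay, going by these compounds alone, the change gives a 96-fold lower number from compound 2 to compound 4 (1.98 log units; beyond the scatter), and only this one group differs between the two compounds. Within the data shown here, this is the first reading of this position with everything else held constant: compound 3 also has a low number, but it differs from compound 2 in more than one place, so it could not show what a ring amine does here by itself. The data shown offer no measured explanation for why the number falls so far.

As far as these compounds go, the step swaps in the piperidine ring and its phenyl together, so their shares of the drop stay unknown; a plain piperidin-1-yl group would begin to separate them. From the compounds shown here alone, how a 4-benzylpiperidin-1-yl group, with one carbon between the two rings, or a 4-(pyridin-4-yl)piperidin-1-yl group would compare also remains open.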